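The compounds below may be only part of what the source reports. "The series", "measured", "known", "first", "only" and "open" are said of these compounds alone.

Compound 1 `CC(=O)C[C@H]1O[C@@H](On2cc(CN3C(=O)/C(=N\Nc4ccccc4)c4ccccc43)nn2)[C@H](OC(C)=O)[C@@H](OC(C)=O)[C@H]1OC(C)=O`, compound 2 `COc1ccc(N/N=C2\C(=O)N(Cc3cn(O[C@@H]4O[C@H](CC(C)=O)[C@H](OC(C)=O)[C@H](OC(C)=O)[C@H]4OC(C)=O)nn3)c3ccccc32)cc1` and compound 3 `CC(=O)C[C@H]1O[C@@H](On2cc(CN3C(=O)/C(=N\Nc4ccc(C#N)cc4)c4ccccc43)nn2)[C@H](OC(C)=O)[C@@H](OC(C)=O)[C@H]1OC(C)=O` share one core and differ only in the substituent on the phenyl ring. In an ADME assay on Vero cells (Chlorocebus sabaeus) for cytotoxicity, read by fluorescence and resazurin assay, with a stated time of 3 days (a higher number here means that more compound is tolerated, a lower number that less compound is tolerated), compound 1 gives 65200 nM, compound 2 gives 62500 nM and compound 3 gives 75500 nM; the three numbers sit within the scatter of one another, so compound 3 is not set apart from either.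

Compound 4 `CC(=O)C[C@H]1O[C@@H](On2cc(CN3C(=O)/C(=N\Nc4cccc(Cl)c4)c4ccccc43)nn2)[C@H](OC(C)=O)[C@@H](OC(C)=O)[C@H]1OC(C)=O` carries 3-chlorophenyl in place of 4-cyanophenyl on an amine nitrogen. Within the data shown here, the steps that bear on this change are those at the same ring: a 1.2-fold higher number from compound 1 to compound 3 (0.06 log units; within the scatter) and a 1.2-fold higher number from compound 2 to compound 3 (0.08 log units; within the scatter), and also a 1.0-fold lower number from compound 1 to compound 2 (0.02 log units; within the scatter). None of them moved the number beyond the scatter, so no step beyond the scatter is expected in this assay here either, a 1.1-fold lower number from compound 3 to compound 4 (0.05 log units; within the scatter). Compound 4 is therefore estimated at 68000 nM, with a range of 35000 nM to 140000 nM.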

Compound 4, half-maximal cytotoxic concentration: 87900 nM
For compound 4 the middle estimate is 1.3-fold (0.11 log units) below the measured one, within the range that was stated.
By their numbers in this assay, from the lowest: compounds 2, 1, 3 and 4 (each within the scatter of the next).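

In this assay, 3-chlorophenyl on the amine nitrogen stays within the scatter of all three earlier groups: a 1.2-fold higher number from compound 3 to compound 4 (0.07 log units; within the scatter), a 1.4-fold higher number from compound 2 to compound 4 (0.15 log units; within the scatter) and a 1.3-fold higher number from compound 1 to compound 4 (0.13 log units; within the scatter). The range of groups tolerated without a step beyond the scatter therefore now includes a chloro group and a substituent placed as in 3-chlorophenyl, not only those of 4-cyanophenyl and 4-methoxyphenyl. No measured evidence bears on this result.

From the compounds shown here alone, whether an amine or a carboxylic acid on the phenyl ring would move the number beyond the scatter remains open. The same applies to a longer chain in place of the phenyl ring.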